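A few compounds are considered here, and "the series" means these few. Any claim that something is new, unique, unknown or untested is made for them only; others in the source may bear on it.

Measured compounds in a functional assay on MDA-MB-231 cells (Homo sapiens) for inhibition, read by MTT assay, with a stated time of 24 h; on this read-out higher numbers stand for weaker inhibition and lower numbers for stronger inhibition:
Compound 1, `CCCCc1cc2ccccc2nc1-c1cc(-c2ccc(F)cc2)no1`, gives 24200 nM.
Compound 2, `CCCCc1cc2ccccc2nc1-c1cc(-c2ccc(C)cc2)no1`, returns only the assay limit, > 100000 nM.
Compound 3, `CCc1cc2ccccc2nc1-c1cc(-c2ccc(C(F)(F)F)cc2)no1`, returns only the assay limit, > 100000 nM.

Compound 3 thus stands at a limit rather than at a number, a position it shares with one other reading in the set (the limit of > 100000 nM in this assay, at which 2 of the 3 values shown sit). Compound 4, `CCCCc1cc2ccccc2nc1-c1cc(-c2ccc(C(F)(F)F)cc2)no1`, keeps the trifluoromethyl-bearing ring of compound 3 and differs from it in one place: ethyl in place of hydrogen on a saturated chain carbon, two bonds along the chain from an aromatic carbon. Going by the values given here, no measured step covers this lengthening of the chain. Among the compounds with values here, the only step known, an at least 4.1-fold higher number from compound 1 to compound 2 (0.61 log units; beyond the scatter), concerns the substituent on the pendant aromatic ring and not the chain, so it offers little guidance for compound 4. Within the data shown here, two of the three readings sit at the limit of this assay, and the one numerical value, that of compound 1, is itself weak. Compound 4 is therefore expected to stay weak, with an estimated value of 100000 nM between 40000 nM and 250000 nM, and a limit reading is the likelier outcome. The step this implies is estimated as a number no higher from compound 3 to compound 4 (the limit leaves the size open), within the scatter.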

Compound 4, half-maximal inhibitory concentration: 10400 nM
Compound 4: middle estimate off by 9.6-fold (0.98 log units), on the high side; measured number outside the range, below it.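

In this assay, going by these compounds alone, ethyl in place of hydrogen on a saturated chain carbon, two bonds along the chain from an aromatic carbon, gives an at least 9.6-fold lower number from compound 3 to compound 4 (0.98 log units; beyond the scatter) and is the first change in the chain with a readable effect. Within the data shown here, with the butyl chain held fixed, trifluoromethyl in place of methyl gives an at least 9.6-fold lower number from compound 2 to compound 4 (0.98 log units; beyond the scatter) and trifluoromethyl in place of fluoro gives a 2.3-fold lower number from compound 1 to compound 4 (0.37 log units; beyond the scatter) as a smaller but still readable shift, so the substituent on the pendant ring can now be ordered beyond the single earlier step. Going by these compounds, the first two of these steps start from a limit, so their full size stays open: the limit of > 100000 nM in this assay, at which 2 of the 4 values shown sit.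

On these data alone, how a propyl chain or a chain longer than butyl would read remains open. So does the effect of an amine or a carboxylic acid on the pendant ring.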